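The source may hold more compounds than are shown below. What is called first, only, known or untested is meant among the compounds shown, and "the series" means these compounds.

Compound 1 `O=C(COc1ccc2cc(/C=C3/SC(=O)NC3=O)ccc2c1)Nc1cccc(Cl)c1`: > 50000 nM
Compound 2 `O=C(COc1ccc2cc(/C=C3/SC(=O)NC3=O)ccc2c1)Nc1c(F)cc(F)cc1Br`: > 50000 nM

In an assay on isolated protein for inhibition of histone deacetylase 8 (Homo sapiens), with a stated time of 1 h (on this read-out higher numbers stand for weaker inhibition and lower numbers for stronger inhibition), compound 1 gives > 50000 nM, and this is a limit of the assay rather than a number. In this assay compound 2 gives > 50000 nM, which is again a limit and not a number. Within the data shown here, the one measured step, a step that the two limits leave unreadable from compound 1 to compound 2, therefore cannot be sized, and compound 2 stands where the numbers give out: both values shown sit at the limit of > 50000 nM in this assay, at which 2 of the 2 values shown sit.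

Compound 3 `O=C(COc1ccc2cc(/C=C3/SC(=O)NC3=O)ccc2c1)Nc1ccc(Br)cc1F` is obtained from compound 2 by the change (4-bromo-2-fluorophenyl in place of 2-bromo-4,6-difluorophenyl on an amide-type nitrogen). Among the measured compounds shown here, no measured step bears directly on this change; the only step between measured compounds, a step that the two limits leave unreadable from compound 1 to compound 2, also alters the aryl group on the amide-type nitrogen, and its size is unreadable. Since compound 1 and compound 2 both sit at the limit of > 50000 nM in this assay, at which 2 of the 2 values shown sit, compound 3 is expected to remain at or close to that limit, so the step of a number no higher from compound 2 to compound 3 (the limit leaves the size open) is expected to be no larger than the scatter. For compound 3 the estimated value in this assay is 50000 nM, within a range of 20000 nM to 200000 nM.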

Compound 3, half-maximal inhibitory concentration: > 50000 nM
Compound 3 was reported as a limit; the forecaster's own chance of this, stated with the estimate: 85%; the middle value sits exactly at the limit.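

In this assay compound 3 gives > 50000 nM, again a limit and not a number. The steps among compound 1, compound 2 and compound 3 therefore cannot be read: the limit of > 50000 nM in this assay, at which 3 of the 3 values shown sit.

The compounds shown leave open how these aryl groups on the amide-type nitrogen would rank, and whether any compound with the shared core gives a readable value.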